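A few compounds are considered here, and "the series" means these few. Any claim that something is new, unique, unknown or untested is made for them only; others in the source may bear on it.

Values in an ADME assay on microsomes from liver (Homo sapiens) for metabolic stability, read by LC-MS, tested at 1 uM (a lower number here means slower removal, a higher number faster removal of the compound), follow
Compound 1 `CC(C)(O)CNCCCOc1ccc([C@H]2CC[C@]3(CC2)OOC2(O3)C3CC4CC(C3)CC2C4)cc1` gives 8 mL.min-1.g-1
Compound 2 `OC1(COc2ccc([C@H]3CC[C@]4(CC3)OOC3(O4)C4CC5CC(C4)CC3C5)cc2)CCNCC1` gives 16 mL.min-1.g-1
Compound 3 `CC(C)(N)CCOc1ccc([C@H]2CC[C@]3(CC2)OOC2(O3)C3CC4CC(C3)CC2C4)cc1` gives < 7 mL.min-1.g-1 as a limit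

Compound 3 stands at the limit of < 7 mL.min-1.g-1 in this assay, at which 1 of the 3 values shown sits, and so has no number of its own. Compound 4 `c1cc([C@H]2CC[C@]3(CC2)OOC2(O3)C3CC4CC(C3)CC2C4)ccc1OC1CCNCC1` differs from it by piperidin-4-yl in place of 3-amino-3-methylbutyl on an oxygen on an aromatic ring in the form of piperidin-4-yl in place of 3-amino-3-methylbutyl on an oxygen on an aromatic ring. The nearest measured step is an at least 2.2-fold lower number from compound 2 to compound 3 (0.35 log units; beyond the scatter) with a ring, the 4-hydroxypiperidin-4-yl, on the side of compound 2. Against a simple ring-versus-chain reading stand a 2.0-fold higher number from compound 1 to compound 2 (0.30 log units; within the scatter) and an at least 1.1-fold lower number from compound 1 to compound 3 (0.05 log units; that floor lies within the scatter) with compound 1 as the exception. A modest step toward faster removal is expected in this assay and is estimated as an at least 1.4-fold higher number from compound 3 to compound 4 (0.15 log units; that floor lies within the scatter) on these grounds. For compound 4 the expected value is 10 mL.min-1.g-1 with an estimated range of 6 mL.min-1.g-1 to 20 mL.min-1.g-1 for now.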

Compound 4, intrinsic clearance in microsomes: 15 mL.min-1.g-1
The estimate for compound 4 lay 1.5-fold (0.18 log units) below the measured number; the measured number falls inside the stated range.
By their numbers in this assay, from the lowest: compounds 1, 4 and 2 (each within the scatter of the next). At a limit, below all of these: compound 3.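

In this assay, piperidin-4-yl in place of 3-amino-3-methylbutyl on an oxygen on an aromatic ring gives a step that exceeds the scatter (an at least 2.1-fold higher number from compound 3 to compound 4 (0.33 log units; beyond the scatter)). Piperidin-4-yl does not separate from (4-hydroxypiperidin-4-yl)methyl (a 1.1-fold lower number from compound 2 to compound 4 (0.03 log units; within the scatter)) or from 3-((2-hydroxy-2-methylpropyl)amino)propyl (a 1.9-fold higher number from compound 1 to compound 4 (0.27 log units; within the scatter)), so any ring-versus-chain reading rests on compound 3 alone, and the open chain of compound 1 goes against it. Compound 3 has only a limit, so its step is a floor: the limit of < 7 mL.min-1.g-1 in this assay, at which 1 of the 4 values shown sits.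

Going by these compounds, the true size of that step remains open. So does the effect of a methyl group on the ring nitrogen of piperidin-4-yl, or of a carboxylic acid in place of the amine.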